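Swapping Acetyl for Cyano on a Sulfonyl-Bearing Chain

The source may hold more compounds than are shown below. What is called first, only, known or untested is meant among the compounds shown, and "the series" means these compounds.

Of the compounds shown here, three have been tested in a functional assay on U-251 cells (Homo sapiens) for inhibition, read by sulforhodamine B assay, with a stated time of 48 h; on this read-out higher numbers stand for weaker inhibition of growth and lower numbers for stronger inhibition of growth. Compound 1 `CCOC(=O)C(=Cc1c(-c2ccccc2)[nH]c2ccccc12)C(=O)OCC` gives 4900 nM, compound 2 `CC(=O)/C(=C\c1c(-c2ccccc2)[nH]c2ccccc12)S(=O)(=O)c1ccccc1` gives 1200 nM, and compound 3 `COc1ccc(-c2[nH]c3ccc(OC)cc3c2C=C(C#N)C#N)cc1` gives 635 nM. Compound 2 therefore holds the second highest of the three numbers: its gap to compound 3 lies within the scatter, while its gap to compound 1 lies beyond it, compound 1 sitting higher.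

Compound 4 `N#C/C(=C\c1c(-c2ccccc2)[nH]c2ccccc12)S(=O)(=O)c1ccccc1` differs from compound 2 in one place only: cyano in place of acetyl on a double-bonded chain carbon bound to a double-bonded chain carbon and a sulfonyl sulfur. Within the data shown here, no pair of measured compounds shows this exact change. Compound 3, which also carries cyano on its chain, gives 635 nM, a number within the scatter of compound 2. The step from compound 2 to compound 4 is therefore expected to be small, a 1.3-fold lower number from compound 2 to compound 4 (0.12 log units; within the scatter), and not beyond the scatter. Compound 4 is estimated at 900 nM, within an expected range of 300 nM to 2700 nM.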

Compound 4, concentration for 50% growth inhibition: 2600 nM
Beside the measured number, compound 4's estimate is 2.9-fold (0.46 log units) below it; measured number inside the range.
By their numbers in this assay, from the lowest: compounds 3 and 2 (each within the scatter of the next); then compounds 4 and 1 (each within the scatter of the next).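

In this assay, cyano in place of acetyl on a double-bonded chain carbon bound to a double-bonded chain carbon and a sulfonyl sulfur gives a 2.2-fold higher number from compound 2 to compound 4 (0.34 log units; beyond the scatter), a modest step. Among these compounds, this is the first direct reading of any single change in this set, and it shows that this position responds to the swap, with acetyl giving the lower number. Nothing at hand explains the direction of this step.

Still open, on these data alone, is how a carboxylic acid or a primary amide at this place would compare with acetyl and cyano. Also open, as far as these compounds go, is whether the same swap gives a step of similar size when the phenylsulfonyl group is replaced by an ethyl ester.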